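Piperazine amide series: chloro for methyl on the benzyl

A few compounds are considered here, and "the series" means these few. Any claim that something is new, unique, unknown or untested is made for them only; others in the source may bear on it.

Measured compounds:
- compound 1, `CN1CCN(CC(=O)Nc2ccc(-c3nc(-c4ccccc4)c(-c4ccccc4)n3C)cc2)CC1`: in a functional assay on MCF7 cells (Homo sapiens) for cytotoxicity, read by MTT assay, with a stated time of 24 h, tested at 6.4 ug/mL (a lower number here means a weaker effect, a higher number a stronger effect of the compound at the concentration tested), compound 1 gives 28.6%
- compound 2, `CCN1CCN(CC(=O)Nc2ccc(-c3nc(-c4ccccc4)c(-c4ccccc4)n3C)cc2)CC1`: in this assay compound 2 gives 16.4%
- compound 3, `Cc1ccc(CN2CCN(CC(=O)Nc3ccc(-c4nc(-c5ccccc5)c(-c5ccccc5)n4C)cc3)CC2)cc1`: in this assay compound 3 gives 21.8%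

Compound 3 stands second highest of the three numbers. Its nearest neighbour is compound 2, a number 5.4 percentage points higher from compound 2 to compound 3 (within the scatter), and the furthest is compound 1, a number 6.8 percentage points lower from compound 1 to compound 3 (within the scatter); both lie within the scatter. Among the measured compounds shown here, the only step beyond the scatter is a number 12.2 percentage points lower from compound 1 to compound 2 (beyond the scatter), and it is a modest one.

Compound 4, `Cn1c(-c2ccc(NC(=O)CN3CCN(Cc4ccc(Cl)cc4)CC3)cc2)nc(-c2ccccc2)c1-c1ccccc1`, differs from compound 3 by chloro in place of methyl on an aromatic carbon; read one bond further out, 4-methylbenzyl becomes 4-chlorobenzyl. For the measured compounds named here, none of the measured steps alters a substituent on that aromatic ring: all three change what is attached to the amine nitrogen in the ring. The two that bring in or replace the 4-methylphenyl, a number 6.8 percentage points lower from compound 1 to compound 3 (within the scatter) and a number 5.4 percentage points higher from compound 2 to compound 3 (within the scatter), both lie within the scatter. The present change swaps one heavy atom for one heavy atom at the outer end of that group, and nothing measured here points to a shift beyond the scatter in this assay in either direction. The expected step is a number 0.2 percentage points higher from compound 3 to compound 4 (within the scatter). Compound 4 is therefore estimated at 22%, with a range from 10% to 35%.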

Compound 4, a percentage reported as activity, at one concentration (the size of the read-out at that concentration, not a potency): 33.4%
Compound 4: middle estimate off by 11.4 percentage points, on the low side; the measured number falls inside the stated range.
By their numbers in this assay, from the lowest: compounds 2, 3, 1 and 4 (each within the scatter of the next, the first and the last beyond it).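

In this assay, among the compounds shown here, chloro in place of methyl on the aromatic carbon para to a large group gives a number 11.6 percentage points higher from compound 3 to compound 4 (beyond the scatter), the first measured change at this position, and it shows that exchanging one heavy atom at the outer end of the benzyl group can produce a step beyond the scatter. The same ring substituent also alters how the benzyl compounds read against the small amine substituents: 4-chlorophenyl in place of methyl on the saturated chain carbon gives a number 17 percentage points higher from compound 2 to compound 4 (beyond the scatter), and 4-chlorophenyl in place of hydrogen there gives a number 4.8 percentage points higher from compound 1 to compound 4 (within the scatter), so compound 4 separates from compound 2 but not from compound 1. No available evidence bears on what lies behind the difference between chloro and methyl at this position.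

Open, as far as these compounds go, is whether this step is particular to chloro or extends to groups such as fluoro, bromo, methoxy or trifluoromethyl on the same carbon, and whether the unsubstituted benzyl reads closer to compound 3 or compound 4. All the readings come from a single concentration, so the compounds shown leave their relative potency open.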